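A few compounds are considered here, and "the series" means these few. Any claim that something is new, unique, unknown or untested is made for them only; others in the source may bear on it.

Compound 1 `O=C(N/N=C\c1cn(Cc2ccc(Cl)cc2)c2cc(F)ccc12)c1c[nH]c2ccccc12` — 18000 nM
Compound 2 `O=C(N/N=C\c1cn(Cc2ccc(Cl)cc2)c2ccccc12)c1c[nH]c2ccccc12` — 44300 nM

For the measured compounds named here, in a functional assay on MIA PaCa-2 cells (Homo sapiens) for cytotoxicity (a higher number here means a weaker inhibitor, a lower number a stronger inhibitor), compound 1 gives the lower of the two numbers; the only measured step, a 2.5-fold higher number from compound 1 to compound 2 (0.39 log units; beyond the scatter), is modest and concerns a different ring of the shared core. Compound 3 `O=C(N/N=C\c1cn(Cc2ccc(Cl)cc2)c2cc(F)ccc12)c1c[nH]c2ccc(Br)cc12` differs from compound 1 by bromo in place of hydrogen on an aromatic carbon. Going by the values given here, no measured step touches this position, so the direction of the change is not indicated by the data. Compound 3 is therefore expected to land near compound 1, with an estimated 1.3-fold lower number from compound 1 to compound 3 (0.11 log units; within the scatter) likely within the scatter. The estimate for compound 3 is 14000 nM, with a range of 5000 nM to 40000 nM.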

Compound 3, half-maximal inhibitory concentration: 10600 nM
Compound 3: middle estimate off by 1.3-fold (0.12 log units), on the high side, and the stated range covers the measured number.
By their numbers in this assay, from the lowest: compounds 3 and 1 (each within the scatter of the next); then compound 2.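

In this assay, for the compounds shown here, the change from 1H-indol-3-yl to 5-bromo-1H-indol-3-yl gives a 1.7-fold lower number from compound 1 to compound 3 (0.23 log units; within the scatter) and is the first reading at this position. A single bromo atom on this ring therefore leaves the number within the scatter of the parent, so this position accepts bromo without a clear change in cytotoxicity. No supporting evidence bears on this result.

Going by these compounds, whether an amine or a carboxylic acid at this position would shift the number beyond the scatter remains open. So does whether bromo here would read the same without the fluoro on the other ring.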